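The source may report more compounds than this note shows. Statements on the series, on what has been measured and on what is new or still open speak of the compounds shown alone.

Compound 1 `Cc1nn(-c2ncnc3nc[nH]c23)c2c1C(OCc1ccccc1F)CC(=O)N2` stands lowest of the three numbers in a functional assay on HEK293 cells for agonist activity at G-protein coupled receptor 39 (Homo sapiens), read by scintillation proximity assay and inositol phosphate accumulation, with a stated time of 75 min (on this read-out lower numbers stand for an effect already at smaller amounts and higher numbers for an effect only at larger amounts of compound), where compound 1 gives 78 nM. Compound 3 `Cc1nn(-c2ncnc3nc[nH]c23)c2c1C(NC(=O)c1ccccc1)CC(=O)N2` gives 158 nM, and compound 2 `Cc1nn(-c2ncnc3nc[nH]c23)c2c1C(OCc1ccc(C(C)C)cc1)CC(=O)N2` gives 1690 nM. Compound 4 `Cc1nn(-c2ncnc3nc[nH]c23)c2c1C(OCCn1cccn1)CC(=O)N2` differs from compound 1 by (1H-pyrazol-1-yl)methyl in place of 2-fluorophenyl on a saturated chain carbon bound to an oxygen on a saturated carbon. Among the measured compounds shown here, two measured steps bear on this position. The change a 22-fold higher number from compound 1 to compound 2 (1.34 log units; beyond the scatter) is large and shows how much the number can rise when the group on that chain carbon is altered, while a 2.0-fold higher number from compound 1 to compound 3 (0.31 log units; beyond the scatter) is modest. Because both steps of a 22-fold higher number from compound 1 to compound 2 (1.34 log units; beyond the scatter) and a 2.0-fold higher number from compound 1 to compound 3 (0.31 log units; beyond the scatter) point upward, compound 4 is expected to show a higher number than compound 1, by a step of roughly a 5.1-fold higher number from compound 1 to compound 4 (0.71 log units; beyond the scatter). The estimate for compound 4 is 400 nM, within a range from 100 nM to 1600 nM.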

Compound 4, half-maximal effective concentration: 2270 nM
For compound 4 the middle estimate is 5.7-fold (0.75 log units) below the measured one, and the stated range ends below it.
By their numbers in this assay, from the lowest: compound 1; then compound 3; then compounds 2 and 4 (each within the scatter of the next).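

In this assay, the step of a 29-fold higher number from compound 1 to compound 4 (1.46 log units; beyond the scatter) shows that replacing 2-fluorophenyl with (1H-pyrazol-1-yl)methyl on this chain carbon costs as much as the 4-isopropylphenyl of compound 2 did, the step of a 1.3-fold higher number from compound 2 to compound 4 (0.13 log units; within the scatter) showing no separation between the two. Two very different groups thus end at a similar level. The 2-(1H-pyrazol-1-yl)ethoxy group also stands well apart from benzamido on the saturated ring carbon, with a step of a 14-fold higher number from compound 3 to compound 4 (1.16 log units; beyond the scatter) in the same direction. Open remains how an unsubstituted phenyl, an amine or a carboxylic acid on that chain carbon would read. Nothing at hand accounts for these steps.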